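The source may hold more compounds than are shown below. What is called first, only, known or untested is meant among the compounds shown, and "the series" means these compounds.

Measured so far:
compound 1, `COc1ccc(/C=N/NC(=O)CSc2nnc(-c3ccncc3)o2)cc1`: 17600 nM
compound 2, `O=C(CSc1nnc(-c2ccncc2)o1)N/N=C/c1cccc(F)c1`: 24900 nM

Both compounds were read in a functional assay on MCF7 cells (Homo sapiens) for cytotoxicity, read by MTT assay, with a stated time of 48 h; on this read-out lower numbers stand for stronger inhibition and higher numbers for weaker inhibition. Compound 1 gives 17600 nM, the lowest of the two numbers shown; its nearest neighbour is compound 2, which gives 24900 nM. Among the measured compounds shown here, the only step between them, a 1.4-fold higher number from compound 1 to compound 2 (0.15 log units; within the scatter), carries 3-fluorophenyl in place of 4-methoxyphenyl on a carbon with a double bond to nitrogen and lies within the scatter, so the two values cannot be ordered against each other.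

Compound 3, `O=C(CSc1nnc(-c2ccncc2)o1)N/N=C/c1ccco1`, has not been measured. Against compound 1 it shows (furan-2-yl in place of 4-methoxyphenyl on a carbon with a double bond to nitrogen). For the measured compounds named here, the one measured step bearing on this position is a 1.4-fold higher number from compound 1 to compound 2 (0.15 log units; within the scatter), which produced no shift beyond the scatter. Nothing measured speaks to furan-2-yl in this place, so the expectation rests on compound 1 and on that single step. The expected step is a 1.3-fold higher number from compound 1 to compound 3 (0.10 log units; within the scatter), nothing beyond the scatter in either direction, with the wider range reflecting the untested ring. Compound 3 is estimated at 22000 nM, with a range from 9000 nM to 55000 nM.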

Compound 3, half-maximal inhibitory concentration: 16600 nM
Compound 3: the middle estimate sits 1.3-fold (0.12 log units) above what was measured; the measured number falls inside the stated range.
By their numbers in this assay, from the lowest: compounds 3, 1 and 2 (each within the scatter of the next).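

In this assay, a five-membered aromatic ring with one hetero atom at this place, furan-2-yl, gives a 1.1-fold lower number from compound 1 to compound 3 (0.03 log units; within the scatter) and also a 1.5-fold lower number from compound 2 to compound 3 (0.18 log units; within the scatter) when set against the other six-membered ring. Among the compounds shown here, the earlier step compared only two substituted phenyl groups, whereas these steps show that changing the ring size and going from 8 to 5 heavy atoms in the group, with the hetero atom now in the ring, leaves compound 1, compound 2 and compound 3 unordered, as every step among them lies within the scatter. No supporting measurement bears on this outcome, and the data offer no explanation for it.

Going by these compounds, it remains open whether any group on the carbon with a double bond to nitrogen can move the number beyond the scatter, for example a cyclohexyl ring, an n-butyl chain, or a phenyl ring carrying an amine or a carboxylic acid. The shared core is the same in all three compounds, so these notes also cannot say how a change elsewhere in it would read in this assay or whether the furan-2-yl result would hold on a different core.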